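Changing the Aryl Group on the Ring Nitrogen

The source may hold more compounds than are shown below. What is called first, only, known or untested is meant among the compounds shown, and "the series" means these compounds.

Of the compounds shown here, three built on one shared core have been tested in a functional assay on the whole organism (strain Swiss albino) for inhibition, with Mus musculus as the target, with stated times of 30 min, 10 min and 20 min; a higher number here means that more compound is needed for the effect, a lower number that less compound is needed. Compound 1 `Cc1ccc(N2CCN(CC(=O)N(c3ccccc3)c3ccccc3)CC2)cc1` carries a 4-methylphenyl group on an amine nitrogen in a ring and gives 31.2 mg/kg. Compound 2 `COc1ccccc1N1CCN(CC(=O)N(c2ccccc2)c2ccccc2)CC1`, with a 2-methoxyphenyl group in that place, gives 12.7 mg/kg, and compound 3 `COc1cccc(N2CCN(CC(=O)N(c3ccccc3)c3ccccc3)CC2)c1`, with a 3-methoxyphenyl group, gives 15.5 mg/kg. Among these three numbers compound 3 stands second highest; its nearest neighbour is compound 2, since a 1.2-fold higher number from compound 2 to compound 3 (0.09 log units; within the scatter), and a 2.0-fold lower number from compound 1 to compound 3 (0.30 log units; within the scatter) also stays within the scatter. Only a 2.5-fold lower number from compound 1 to compound 2 (0.39 log units; beyond the scatter) reaches beyond it.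

Compound 4 `O=C(CN1CCN(c2ccc(F)cc2)CC1)N(c1ccccc1)c1ccccc1` has not yet been measured. It differs from compound 3 in one place: 4-fluorophenyl in place of 3-methoxyphenyl on an amine nitrogen in a ring. Within the data shown here, no measured step exchanges a methoxy group for a fluorine, so the closest guides are compound 1 with its 4-methylphenyl group, which gives 31.2 mg/kg, together with the step of a 2.0-fold lower number from compound 1 to compound 3 (0.30 log units; within the scatter). Because a 2.0-fold lower number from compound 1 to compound 3 (0.30 log units; within the scatter) and a 1.2-fold higher number from compound 2 to compound 3 (0.09 log units; within the scatter) both stay within the scatter, compound 4 is expected to land close to compound 3, perhaps slightly higher, with an expected step of a 1.3-fold higher number from compound 3 to compound 4 (0.11 log units; within the scatter). The estimate for compound 4 in this assay is 20 mg/kg, with a range from 10 mg/kg to 40 mg/kg.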

Compound 4, dose for half-maximal effect: 20 mg/kg
For compound 4 middle estimate and measured number coincide at the digits printed; the measured number falls inside the stated range.
By their numbers in this assay, from the lowest: compounds 2, 3, 4 and 1 (each within the scatter of the next, the first and the last beyond it).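

In this assay, the change to a 4-fluorophenyl group gives a 1.3-fold higher number from compound 3 to compound 4 (0.11 log units; within the scatter), and the comparison with the other methoxy compound gives a 1.6-fold higher number from compound 2 to compound 4 (0.20 log units; within the scatter). The group on the ring nitrogen can therefore go from 1 hydrogen-bond acceptor to 0, losing its oxygen, without a change that can be told from the scatter. The comparison with the 4-methylphenyl compound isolates one small exchange, fluoro in place of methyl on an aromatic carbon, and gives a 1.6-fold lower number from compound 1 to compound 4 (0.19 log units; within the scatter), so this exchange also stays inside the scatter, and no data on hand say why these four numbers lie as close as they do.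

The four compounds carry only a methyl, a methoxy or a fluoro on the phenyl ring, which leaves open whether a carboxylic acid, an amine or a trifluoromethyl group in that place would move the number beyond the scatter. Also open, on these data alone, is how far the number depends on where the fluoro sits on the ring, and whether the aromatic ring itself can give way to a longer chain.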